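The compounds below may be only part of what the source reports. "The series", "measured", "known", "first", "only" and "open" are said of these compounds alone.

The shared core is that of compound 1 `COc1cc(-c2nnc(SCC(=O)c3cccc(Br)c3)n2N)cc(OC)c1OC`, which in a functional assay on HeLa cells (Homo sapiens) for antiproliferative activity, read by MTT assay, with a stated time of 48 h (a higher number here means a weaker inhibitor, a lower number a stronger inhibitor), gives 77500 nM. Compound 2 `COc1cc(-c2nnc(SCC(=O)c3ccc(F)c(F)c3)n2N)cc(OC)c1OC` differs from it only in the group on the carbonyl carbon. In this assay compound 2 is reported only as a limit, > 100000 nM. The step of an at least 1.2-fold higher number from compound 1 to compound 2 (0.11 log units; that floor lies within the scatter) is therefore known only as a floor. Compound 3 `COc1cc(NC(=O)CSc2nnc(-c3cc(OC)c(OC)c(OC)c3)n2N)cc(OC)c1OC`, in which the carbonyl carbon carries an amine rather than a ring, also sits at a limit in this assay, > 100000 nM. So compound 2 stands at the limit alongside compound 3, and compound 1 is the only one of the three with a number; the limit of > 100000 nM in this assay, at which 2 of the 3 values shown sit, marks where two of the three values sit.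

Compound 4 `COc1cc(-c2nnc(SCC(=O)NCc3ccc(Cl)cc3)n2N)cc(OC)c1OC` is not yet measured. Its change from compound 2 is (4-chlorobenzyl)amino in place of 3,4-difluorophenyl on a carbonyl carbon. Among the compounds with values here, only one measured step touches this position, from compound 1 to compound 2, and it reaches just a floor. Within the data shown here, no measured step exchanges a ring for an amine on the carbonyl carbon, although compound 3 shows that such an amide also lands at the limit. Compound 4 is therefore expected to stay at or near the limit, with no step beyond the scatter anticipated, that is a step of a number no higher from compound 2 to compound 4 (the limit leaves the size open). In this assay compound 4 is estimated at 100000 nM, within a range from 40000 nM to 250000 nM.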

Compound 4, half-maximal inhibitory concentration: > 100000 nM
Compound 4: no number, only a limit; the forecaster's own chance of this, stated with the estimate: 60%; the middle value lies on the limit itself.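

The new result adds one readable step, an at least 1.2-fold higher number from compound 1 to compound 4 (0.11 log units; that floor lies within the scatter), so this exchange, like the one to 3,4-difluorophenyl, is known only as a floor and does not separate compound 4 from compound 1. The step linking compound 2 and compound 4 cannot be read, as both are limits. What compound 4 adds is that a carbonyl carbon carrying (4-chlorobenzyl)amino, with its amide hydrogen and its chlorine, also ends at a limit, so a ring set directly on that carbon and an amino group bearing a benzyl chain both appear there, with compound 1 the only compound shown that has a number: the limit of > 100000 nM in this assay, at which 3 of the 4 values shown sit.

The compounds shown leave open how far past that limit compound 2, compound 3 and compound 4 truly lie, so any differences among them remain unknown. They also leave open how a morpholine or a longer chain such as phenethylamino on the carbonyl carbon would read in this assay, and whether any group at this position gives a value clearly stronger than that of compound 1.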